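The compounds below may be only part of what the source reports. "The series", "measured", "known", "first", "only" and "open" are said of these compounds alone.

Measured compounds:
compound 1, `CCCc1nc2c(C)cc(NC(=O)CC)cc2n1Cc1ccc(-c2ccccc2C(=O)O)cc1`: 78 nM
compound 2, `CCCc1nc2c(C)cc(NC(=O)CCc3ccccc3)cc2n1Cc1ccc(-c2ccccc2C(=O)O)cc1`: 149 nM

In an assay on isolated protein for displacement of a labelled ligand from Type-2 angiotensin II receptor (Homo sapiens), with a stated time of 180 min (on this read-out higher numbers stand for weaker inhibition and lower numbers for stronger inhibition), compound 2 gives 149 nM, the higher of the two numbers shown, with compound 1 nearest at 78 nM; the gap between them, a 1.9-fold higher number from compound 1 to compound 2 (0.28 log units; within the scatter), lies within the scatter. Compound 3, `CCCc1nc2c(C)cc(NC(=O)OC)cc2n1Cc1ccc(-c2ccccc2C(=O)O)cc1`, differs from compound 2 by methoxy in place of phenethyl on a carbonyl carbon. Among the measured compounds shown here, the only measured step that bears on this change is the one in which the phenyl was introduced, a 1.9-fold higher number from compound 1 to compound 2 (0.28 log units; within the scatter), and it was small. Taking the phenethyl away again, with methoxy entering, is therefore expected to give at most a small step in this assay, if anything towards a lower number. For the measured compounds named here, no measured pair tests the entry of methoxy on its own, so that part of the change is untested. Compound 3 is expected to give 90 nM, within a range from 30 nM to 270 nM. The step of a 1.7-fold lower number from compound 2 to compound 3 (0.22 log units; within the scatter) is thus estimated to stay within the scatter.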

Compound 3, half-maximal inhibitory concentration: 4370 nM
Estimate against measurement, compound 3: 49-fold (1.69 log units) below; measured number above the stated range.
By their numbers in this assay, from the lowest: compounds 1 and 2 (each within the scatter of the next); then compound 3.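

In this assay, the group on this carbonyl carbon turns out to matter a great deal: methoxy in place of phenethyl gives a 29-fold higher number from compound 2 to compound 3 (1.47 log units; beyond the scatter), and methoxy in place of ethyl gives a 56-fold higher number from compound 1 to compound 3 (1.75 log units; beyond the scatter). The earlier step, a 1.9-fold higher number from compound 1 to compound 2 (0.28 log units; within the scatter), had shown only that ethyl and phenethyl could not be told apart. Since methoxy gives a large step from both, the rise goes with the entry of methoxy and not with the loss of the phenyl ring alone, and no measurement shown here gives a reason for it.

On these data alone, whether the oxygen attached to the carbonyl carbon is what matters stays open, as does whether ethoxy or benzyloxy would behave like methoxy. Also open, as far as these compounds go, is how a methylamino group or a plain methyl group would compare on the same carbonyl carbon.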